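The source may hold more compounds than are shown below. What is called first, only, known or untested is meant among the compounds shown, and "the series" means these compounds.

Series notes. Among the measured compounds shown here, in a functional assay on MCF7 cells (Homo sapiens) for inhibition, read by MTT assay, with a stated time of 72 h (on this read-out lower numbers stand for stronger inhibition of growth and higher numbers for weaker inhibition of growth), compound 3 `O=S(=O)(NCCCNCc1ccc(-c2ccccc2)cc1)c1cc(C(F)(F)F)cc(C(F)(F)F)c1` gives 1700 nM, the lowest of the three numbers measured so far. Compound 1 `O=S(=O)(NCCCNCc1ccc(Cl)cc1)c1cc(C(F)(F)F)cc(C(F)(F)F)c1` gives 2400 nM, and compound 2 `O=S(=O)(NCCNCc1cccc2ccccc12)c1cc(C(F)(F)F)cc(C(F)(F)F)c1` gives 18000 nM; the values of compound 3 and compound 2 lie well apart, whereas the step of a 1.4-fold lower number from compound 1 to compound 3 (0.15 log units; within the scatter) stays within the scatter. Compound 4 `COc1ccc(CNCCCNS(=O)(=O)c2cc(C(F)(F)F)cc(C(F)(F)F)c2)cc1` differs from compound 3 by methoxy in place of phenyl on an aromatic carbon. For the measured compounds named here, only the step from compound 1 to compound 3 bears on this change, and it was small, so no shift beyond the scatter is expected in this assay, with at most a mild drift toward a higher number. Compound 4 is therefore estimated at 2500 nM, with a range of 1000 nM to 6000 nM. The expected step is a 1.5-fold higher number from compound 3 to compound 4 (0.17 log units; within the scatter).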

Compound 4, concentration for 50% growth inhibition: 2500 nM
Estimate against measurement, compound 4: no gap at the digits printed; the measured number falls inside the stated range.
By their numbers in this assay, from the lowest: compounds 3, 1 and 4 (each within the scatter of the next); then compound 2.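

In this assay, methoxy on this aromatic carbon, para to a large group, gives a 1.5-fold higher number from compound 3 to compound 4 (0.17 log units; within the scatter) and a 1.0-fold higher number from compound 1 to compound 4 (0.02 log units; within the scatter), so both steps stay within the scatter. Phenyl, chloro and methoxy at this place therefore cannot be told apart on this read-out, even though the change from phenyl to methoxy goes from 6 heavy atoms to 2 and removes the ring. No data bearing on the reason for this are at hand.

As far as these compounds go, whether an amine or a carboxylic acid at this place would move the number beyond the scatter remains open. From the compounds shown here alone, the effect of a longer chain in the linker also remains open, as compound 2 differs from the other compounds in more than one place.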